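Stereoisomers at the Tolerance Limit of a Cell Assay

A few compounds are considered here, and "the series" means these few. Any claim that something is new, unique, unknown or untested is made for them only; others in the source may bear on it.

Compound 1 `Nc1nc2c(ncn2/C=C2\C[C@@H]2[C@@H](O)CO)c(=O)[nH]1`: > 300000 nM
Compound 2 `Nc1nc2c(ncn2/C=C2\C[C@H]2[C@@H](O)CO)c(=O)[nH]1`: 298000 nM
Compound 3 `Nc1nc2c(ncn2/C=C2\C[C@H]2[C@H](O)CO)c(=O)[nH]1`: > 300000 nM

These three compounds have the same atoms and bonds and differ only in their arrangement in space. In an ADME assay on HFF cells (Homo sapiens) for cytotoxicity, read by neutral red uptake (a higher number here means that more compound is tolerated, a lower number that less compound is tolerated), compound 3 stands at > 300000 nM, which is a limit and not a number. Compound 1 also gives only a limit, > 300000 nM. Going by the values given here, compound 2 is the only one with a number, 298000 nM.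

Compound 4 `Nc1nc2c(ncn2/C=C2/C[C@@H]2[C@H](O)CO)c(=O)[nH]1` again keeps every atom and bond of compound 3, and the change is purely one of configuration: the two compounds have the same atoms and bonds and differ only in configuration as drawn: 2 of 3 stereo elements differ; a stereocentre at a saturated ring carbon is drawn R in compound 3 and S in compound 4; a double bond is drawn E in compound 3 and Z in compound 4.

Among the compounds with values here, three measured steps bear on this: a number no higher from compound 1 to compound 2 (the limit leaves the size open), a number no lower from compound 2 to compound 3 (the limit leaves the size open) and a step that the two limits leave unreadable from compound 1 to compound 3. Each of them runs into the limit, so none has a readable size. Within the data shown here, they cover changes at the ring and chain stereocentres, but no measured compound differs at the double bond, so that half of the change is untested. No step beyond the usual scatter is therefore expected, although the untested double bond leaves more room downward than upward, and compound 4 may also be reported only as a limit. The expected change is an at least 1.0-fold lower number from compound 3 to compound 4 (0.02 log units; that floor lies within the scatter). Compound 4 is estimated at 280000 nM, with an expected range from 120000 nM to 400000 nM.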

Compound 4, half-maximal cytotoxic concentration: > 300000 nM
Compound 4 gave a limit, no number (the forecaster's own chance of this, stated with the estimate: 60%); middle value at least 1.0-fold (0.02 log units) away from the limit.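

In this assay compound 4 gives > 300000 nM, which is a limit and not a number. This is the first compound shown with the double bond drawn Z, and it does not give a measured value as compound 2 does. None of the steps to compound 4 has a readable size, and one fact accounts for this: the limit of > 300000 nM in this assay, at which 3 of the 4 values shown sit.

Compound 4 differs from each of the other compounds in at least two stereo elements, so the double bond is never tested alone and its share cannot be separated from that of the stereocentres. What can be read is a number no lower from compound 2 to compound 4 (the limit leaves the size open) and nothing more.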